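This account rests on a few compounds, and the source may have more. Where it says the series, first, only, none or still open, it means among the compounds named here.

Of the compounds shown here, two built on one shared core have been measured so far. Compound 1 `COc1c(C)cnc(CN2c3nc(N)nc(Cl)c3NC(=O)[C@H]2C)c1C` is the stronger of the pair: in a functional assay on SK-BR-3 cells (Homo sapiens) for inhibition (on this read-out higher numbers stand for weaker inhibition and lower numbers for stronger inhibition), compound 1 gives 220 nM. Compound 2 `COc1c(C)cnc(CN2CC(=O)N(CCCC(C)C)c3c(Cl)nc(N)nc32)c1C` is the weaker: in this assay compound 2 gives 970 nM, the highest of the two numbers, and the nearest value, that of compound 1, lies lower by a gap beyond the usual scatter. Compound 3 `COc1c(C)cnc(CN2CC(=O)N(CCN3CCCC3)c3c(Cl)nc(N)nc32)c1C` has not yet been measured. It differs from compound 2 in a single place: pyrrolidin-1-yl in place of isobutyl on a saturated chain carbon, two bonds along the chain from an amide-type nitrogen in a ring. Among the compounds with values here, no measured pair shows this exchange, so the data give no direct guide to its size. A small movement in this assay is expected, not clearly beyond the scatter, with no firm direction. The expected step is a 1.4-fold lower number from compound 2 to compound 3 (0.14 log units; within the scatter). Compound 3 is estimated at 700 nM, within a range from 250 nM to 2000 nM.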

Compound 3, half-maximal inhibitory concentration: 300 nM
The estimate for compound 3 lay 2.3-fold (0.37 log units) above the measured number; measured number inside the range.
By their numbers in this assay, from the lowest: compounds 1 and 3 (each within the scatter of the next); then compound 2.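

On a saturated chain carbon, two bonds along the chain from an amide-type nitrogen in a ring, the group at the end of the chain clearly matters in this assay: pyrrolidin-1-yl in place of isobutyl gives a 3.2-fold lower number from compound 2 to compound 3 (0.51 log units; beyond the scatter) and so stronger inhibition. Within the data shown here, the earlier compounds offered no pair that differed at this place, so this is the first sign that the position responds to change. The exchange replaces a branched all-carbon end with a five-membered ring that holds one nitrogen and one hydrogen-bond acceptor.

Going by these compounds, whether the ring, the nitrogen or both go with the lower number stays open, and cyclopentyl, dimethylamino or piperidin-1-yl on the same chain could separate these. No separate measurement bears on the reason for this step.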